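The source may report more compounds than this note shows. Statements on the series, on what has been measured and on what is new or still open speak of the compounds shown alone.

In a functional assay on the whole organism with Mus musculus as the target (a lower number here means that less compound is needed, a higher number that more compound is needed for the effect), the measured compounds stand as follows

- compound 1 (`CCn1nc(-c2ccc(Cl)cc2)n(C)c1=S`) gives 100 mg/kg
- compound 2 (`Cn1nc(-c2ccc(F)cc2)n(C)c1=S`) gives 1 mg/kg
- compound 3 (`COc1ccc(-c2nn(C)c(=S)n2C)cc1`) gives 3.3 mg/kg

Compound 3 (3.3 mg/kg) holds the second highest of the three numbers. Compound 2 (1 mg/kg) sits lower, and compound 1 (100 mg/kg) sits well higher.

The next compound to be measured is compound 4 (`Cn1nc(-c2ccc(Cl)cc2)n(C)c1=S`). Its structure differs from compound 3 by chloro in place of methoxy on an aromatic carbon.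

Within the data shown here, only one measured step involves a single change on this aromatic carbon: methoxy in place of fluoro (a 3.3-fold higher number from compound 2 to compound 3 (0.52 log units; beyond the scatter)). That step is modest, though beyond the scatter. Compound 1 also carries chloro, but its structure differs from compound 4 elsewhere as well. The value of compound 1 (100 mg/kg) therefore cannot be assigned to the chloro group alone, and it serves only as a caution on the high side.

Among the measured compounds shown here, no measurement yet compares chloro directly with methoxy on the shared core. A step no larger than the modest one measured is expected, with no firm direction. In this assay the expected outcome is therefore a 1.3-fold lower number from compound 3 to compound 4 (0.12 log units; within the scatter) (no move beyond the scatter is expected).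

For compound 4 the estimated value is 2.5 mg/kg (expected range 0.8 mg/kg to 10 mg/kg).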

Compound 4, dose for half-maximal effect: 0.27 mg/kg
Compound 4: the middle estimate sits 9.3-fold (0.97 log units) above what was measured, outside the stated range (below it).
By their numbers in this assay, from the lowest: compound 4; then compound 2; then compound 3; then compound 1.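

In this assay, the aromatic carbon para to a group of 8 heavy atoms responds strongly to the choice of substituent: chloro in place of methoxy gives a 12-fold lower number from compound 3 to compound 4 (1.09 log units; beyond the scatter), and chloro in place of fluoro gives a 3.7-fold lower number from compound 2 to compound 4 (0.57 log units; beyond the scatter), so among these compounds the number rises from chloro through fluoro to methoxy, with every step beyond the scatter. Compound 1 can now be read as a single change, since hydrogen in place of methyl on the saturated chain carbon bound to an aromatic nitrogen gives a 370-fold lower number from compound 1 to compound 4 (2.57 log units; beyond the scatter), which places its high value on the chain and not on chloro. Nothing measured here offers a reason for either effect.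

As far as these compounds go, the chain change is read only with chloro on the aromatic carbon, so its size with fluoro or methoxy there remains open. Also open, from the compounds shown here alone, is whether a nitrile, a trifluoromethyl or an amine at this carbon would give a number lower than that of compound 4 at 0.27 mg/kg.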